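This account rests on a few compounds, and the source may have more. Where it says the series, first, only, none or still open, it means among the compounds named here.

Measured compounds in a functional assay on the whole organism (strain Wistar) for inhibition, with Rattus norvegicus as the target, read by paw edema, with stated times of 30 min and 5 h, at a dose of 100 mg/kg by the oral route; a lower number here means less inhibition, a higher number more inhibition at the dose given (going by the name of the read-out):

Compound 1, `CC(=O)c1ccc(N)c(OC2CCCCC2)c1`, gives 19% in this assay.
Compound 2, `CCCCCOc1cc(C(C)=O)ccc1NS(C)(=O)=O`, gives 59.6% in this assay.
Compound 3, `CCCCCCOc1cc(C(C)=O)ccc1NS(C)(=O)=O`, gives 76.8% in this assay.

Compound 3 stands highest of the three numbers. Within the data shown here, its nearest neighbour is compound 2, reached through the step of a number 17.2 percentage points higher from compound 2 to compound 3 (beyond the scatter), which is the only step among the measured compounds that changes one place at a time. Compound 1 lies far below compound 3, but the two differ in more than one place, so their values can only be compared as they stand.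

Compound 4, `CC(=O)c1ccc(NS(C)(=O)=O)c(OC2CCCCC2)c1`, differs from compound 3 in one place: cyclohexyl in place of hexyl on an oxygen on an aromatic ring. Among the measured compounds shown here, no measured step concerns this exchange of a hexyl for a cyclohexyl, so the size of the step is uncertain. The step from compound 2 to compound 3 shows that the group on that oxygen does matter, in a modest way. Compound 1 also carries a cyclohexyl on that oxygen, but it lacks the methanesulfonamide of compound 4, so its low value is not a direct guide. Compound 4 is therefore expected to stay in the same broad region as compound 3, most likely somewhat lower, around 62%, with a wide range from 38% to 84%. For compound 4 this amounts to an expected step of a number 14.8 percentage points lower from compound 3 to compound 4 (beyond the scatter).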

Compound 4, a percentage reported as inhibition, in the whole organism at one dose (the size of the read-out at that dose, not a potency): 73.7%
Estimate against measurement, compound 4: 11.7 percentage points below; measured number inside the range.
By their numbers in this assay, from the lowest: compound 1; then compound 2; then compounds 4 and 3 (each within the scatter of the next).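

In this assay, cyclohexyl in place of hexyl on an oxygen on an aromatic ring gives a number 3.1 percentage points lower from compound 3 to compound 4 (within the scatter) and so the ring and the open chain, both of the same carbon count, cannot be told apart at this position. Cyclohexyl in place of pentyl gives a number 14.1 percentage points higher from compound 2 to compound 4 (beyond the scatter) and this shows that a ring at this position can reach the level that the hexyl chain reaches. With the cyclohexyl held in place, the methylsulfonyl on the nitrogen accounts for a number 54.7 percentage points higher from compound 1 to compound 4 (beyond the scatter) and this is the largest single change shown, far greater than any change on the oxygen. No evidence on hand explains these steps.

Still open, from the compounds shown here alone, is whether a longer chain such as octyl, or a smaller ring such as cyclopentyl, would hold these numbers. Also open, going by these compounds, is whether an acetyl or benzoyl group on that nitrogen could stand in for the methylsulfonyl.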